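Working notes on the shared core: compound 3 to compound 4

A few compounds are considered here, and "the series" means these few. Any claim that something is new, unique, unknown or untested is made for them only; others in the source may bear on it.

Measured so far in an ADME assay on CCRF-HSB-2 cells (Homo sapiens) for cytotoxicity, with a stated time of 7 days; a higher number here means that more compound is tolerated, a lower number that less compound is tolerated:
- compound 1 `Nc1nc(NCc2ccccc2)c2ncn(/C=C3/CC3(CO)CO)c2n1` gives > 20000 nM, which is a limit of the assay.
- compound 2 `Nc1nc2c(ncn2/C=C2/CC2(CO)CO)c(=O)[nH]1` gives > 20000 nM, which is a limit of the assay.
- compound 3 `Nc1nc(N2CCCC2)c2ncn(/C=C3/CC3(CO)CO)c2n1` gives > 20000 nM, which is a limit of the assay.

Compound 3 stands at the limit of > 20000 nM in this assay, at which 3 of the 3 values shown sit. No numbered value exists for it, only the limit. Among the measured compounds shown here, the single step between measured compounds, a step that the two limits leave unreadable from compound 1 to compound 3, runs from one limit to another and therefore has no readable size or direction.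

The next compound, compound 4 `CCCCOc1nc(N)nc2c1ncn2/C=C1/CC1(CO)CO`, differs from compound 3 in one place: butoxy in place of pyrrolidin-1-yl on an aromatic carbon. For the measured compounds named here, no measured step exchanges these two groups; the one step that exists exchanges a different pair and is itself unreadable, so there is no measured guide to the size of this change.

Because every value shown sits at the limit of > 20000 nM in this assay, at which 3 of the 3 values shown sit, no step beyond the scatter is expected in this assay for this change, in either direction. Compound 4 is expected to give about 30000 nM, between 10000 nM and 100000 nM, most probably again reported only as a limit. The estimated step is a step that the limit leaves unreadable from compound 3 to compound 4, none beyond the scatter.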

Compound 4, half-maximal cytotoxic concentration: > 20000 nM
Compound 4: a limit, no number; the forecaster's own chance of this, stated with the estimate: 85%; the middle value is on the limit's open side.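

In this assay compound 4 gives > 20000 nM, which is a limit of the assay. Its steps from compound 3 and from compound 1 run between limits and cannot be read.

The compounds shown leave open at what concentration any of them becomes cytotoxic, and whether exchanging benzylamino, pyrrolidin-1-yl and butoxy changes that concentration at all.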